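Aromatic amide swap on the shared core: compound 3

The source may hold more compounds than are shown below. What is called first, only, known or untested is meant among the compounds shown, and "the series" means these compounds.

Measured so far:
- compound 1 `O=C(CN1CC=CC[C@H](NC(=O)c2cc(Cl)ccc2Cl)C1=O)N[C@H]1CC(=O)OC1O` gives 71 nM in a functional assay on THP-1 cells (Homo sapiens) for inhibition; a higher number here means a weaker inhibitor, a lower number a stronger inhibitor
- compound 2 `O=C(CN1CC=CC[C@H](NC(=O)c2cccc(Cl)c2)C1=O)N[C@H]1CC(=O)OC1O` gives 383 nM in this assay

Among the compounds with values here, of these two numbers, compound 2 stands highest, with compound 1 the only neighbour. Compound 3 `O=C(CN1CC=CC[C@H](NC(=O)c2cc3ccccc3s2)C1=O)N[C@H]1CC(=O)OC1O` brings 1-benzothiophen-2-yl in place of 3-chlorophenyl on a carbonyl carbon on the shared core. Within the data shown here, the one measured step bearing on this is a 5.4-fold higher number from compound 1 to compound 2 (0.73 log units; beyond the scatter) and it concerns the same aromatic group, though it is a different swap. A modest move to a lower number is expected in this assay and the estimated step is a 2.3-fold lower number from compound 2 to compound 3 (0.35 log units; beyond the scatter) on this single precedent. Compound 3 is expected at 170 nM within a range of 45 nM to 600 nM on present data.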

Compound 3, half-maximal inhibitory concentration: 712 nM
Beside the measured number, compound 3's estimate is 4.2-fold (0.62 log units) below it; measured number above the stated range.
By their numbers in this assay, from the lowest: compound 1; then compounds 2 and 3 (each within the scatter of the next).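

In this assay, 1-benzothiophen-2-yl on a carbonyl carbon does not separate from 3-chlorophenyl (a 1.9-fold higher number from compound 2 to compound 3 (0.27 log units; within the scatter)). Against 2,5-dichlorophenyl, the same group gives a clear loss (a 10-fold higher number from compound 1 to compound 3 (1.00 log units; beyond the scatter)), so among the three aromatic groups shown, only 2,5-dichlorophenyl stands apart, with compound 1 lowest. No measured evidence accounts for these steps.

Still open, on these data alone, is whether a 1-benzothiophen-2-yl group bearing chloro would recover the value of compound 1. Also open, as far as these compounds go, is how a phenyl group carrying an amine or a carboxylic acid at this place would compare.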